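Cytotoxicity notes on a glycosylated triazole oxindole hydrazone series

The source may hold more compounds than are shown below. What is called first, only, known or untested is meant among the compounds shown, and "the series" means these compounds.

Measured so far:
Compound 1 `CC(=O)C[C@H]1O[C@@H](On2cc(CN3C(=O)/C(=N\Nc4ccc(Br)cc4)c4ccccc43)nn2)[C@H](OC(C)=O)[C@@H](OC(C)=O)[C@H]1OC(C)=O` gives 83400 nM in an ADME assay on Vero cells (Chlorocebus sabaeus) for cytotoxicity, read by fluorescence and resazurin assay, with a stated time of 3 days; on this read-out lower numbers stand for higher toxicity in this test and higher numbers for lower toxicity in this test.
Compound 2 `COc1ccc(N/N=C2\C(=O)N(Cc3cn(O[C@@H]4O[C@H](CC(C)=O)[C@H](OC(C)=O)[C@H](OC(C)=O)[C@H]4OC(C)=O)nn3)c3ccccc32)cc1` gives 62500 nM in this assay.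
Compound 3 `O=C1/C(=N\Nc2ccc(Br)cc2)c2ccccc2N1Cc1cn(O[C@@H]2O[C@H](CO)[C@H](O)[C@H](O)[C@H]2O)nn1` gives 91500 nM in this assay.

Compound 1 and compound 2 differ by methoxy in place of bromo on an aromatic carbon and the step is a 1.3-fold lower number from compound 1 to compound 2 (0.13 log units; within the scatter). Compound 3 carries a core of a different kind from compound 1; the difference between the two cores is not broken down here. Compound 3 and compound 1 give values that lie within the scatter of one another, as do compound 3 and compound 2.

Compound 4 `COc1ccc(N/N=C2\C(=O)N(Cc3cn(O[C@@H]4O[C@H](CO)[C@H](O)[C@H](O)[C@H]4O)nn3)c3ccccc32)cc1` is not yet measured. It differs from compound 3 by methoxy in place of bromo on an aromatic carbon, the same change as from compound 1 to compound 2, made on the core of compound 3. The step from compound 3 to compound 4 is expected to be a 1.3-fold lower number from compound 3 to compound 4 (0.12 log units; within the scatter) in this assay, beside the earlier one, because a 1.3-fold lower number from compound 1 to compound 2 (0.13 log units; within the scatter) stayed within the scatter and nothing in the three values suggests the core of compound 3 behaves otherwise. Compound 4 is therefore estimated at 70000 nM, with a range from 40000 nM to 120000 nM.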

Compound 4, half-maximal cytotoxic concentration: 76200 nM
The estimate for compound 4 lay 1.1-fold (0.04 log units) below the measured number, within the range that was stated.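

In this assay, methoxy in place of bromo on the core of compound 3 gives a 1.2-fold lower number from compound 3 to compound 4 (0.08 log units; within the scatter), and this step sits with the earlier one on the core of compound 1: the same change on two cores in this assay, a 1.3-fold lower number (0.13 log units; within the scatter) from compound 1 to compound 2 and a 1.2-fold lower number (0.08 log units; within the scatter) from compound 3 to compound 4, 1.1-fold (0.05 log units) apart, within the scatter of two such steps. The change therefore carries between these two cores with no difference that can be told apart in this test, and on neither core does it move the number beyond the scatter. This is a reading from two small steps on two cores in one assay; it does not establish a general rule for the series, and it does not show how the change would behave on any other core.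

The aromatic position shown, para to a large group, carries only bromo or methoxy, so it remains open whether an amine, a carboxylic acid or a longer chain there would stay within the scatter. Also open, from the compounds shown here alone, is whether any such group would carry equally between the two cores.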